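A changed 1,2-oxazole group awaiting its measurement

The compounds below may be only part of what the source reports. "The series", "measured", "known", "first", "only" and "open" are said of these compounds alone.

Measured so far in a functional assay on the whole organism (strain C57BL/6) for inhibition, with Mus musculus as the target, read by microscopy, with a stated time of 6 days, at a dose of 10 mg/kg by the oral route; a higher number here means more inhibition at the dose given (going by the name of the read-out), a lower number less inhibition:
compound 1 `Nc1cc(Oc2ccc3c(ccn3C(=O)Nc3cccc(C(F)(F)F)c3)c2)ncn1` gives 44%
compound 2 `CC(C)(C)c1cc(NC(=O)n2ccc3cc(Oc4ncnc5c4CNC5)ccc32)on1` gives 58%

Compound 2 stands highest of these two numbers; compound 1 sits lower by a margin beyond the usual scatter, so the two compounds are genuinely separated in this assay.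

Compound 3 `CC1(c2cc(NC(=O)n3ccc4cc(Oc5ncnc6c5CNC6)ccc43)no2)CC1` has not yet been measured. It differs from compound 2 in one place: 5-(1-methylcyclopropyl)-1,2-oxazol-3-yl in place of 3-(tert-butyl)-1,2-oxazol-5-yl on an amide-type nitrogen. The group that leaves and the group that enters are alike in what is counted, and the only shift is from a tert-butyl to a 1-methylcyclopropyl on a 1,2-oxazolyl ring that is joined to the amide-type nitrogen through another of its ring atoms.

Among the compounds with values here, no measured pair in this set shows what such a swap does, so the numbers give no direction for it. The step in this assay is therefore expected to be small, within the scatter, and of no fixed sign: a number 3 percentage points lower from compound 2 to compound 3 (within the scatter). Compound 3 is estimated at 55%, in a range from 35% to 75%.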

Compound 3, a percentage reported as inhibition, in the whole organism at one dose (the size of the read-out at that dose, not a potency): 90%
Compound 3: the middle estimate sits 35 percentage points below what was measured; measured number above the stated range.
By their numbers in this assay, from the lowest: compound 1; then compound 2; then compound 3.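

In this assay, putting 5-(1-methylcyclopropyl)-1,2-oxazol-3-yl in place of 3-(tert-butyl)-1,2-oxazol-5-yl on the amide-type nitrogen gives a number 32 percentage points higher from compound 2 to compound 3 (beyond the scatter), so this position can strongly change the read-out even when the groups that leave and enter are alike in what is counted. The swap makes two changes at once, adding a three-membered ring of carbon only and joining the 1,2-oxazolyl ring to the nitrogen through another of its ring atoms, and this single pair cannot separate their contributions. Nothing available here explains the gain.

The compounds shown leave open how 5-(tert-butyl)-1,2-oxazol-3-yl would read on the same nitrogen, a comparison that would keep the ring joined as in compound 3 while restoring the tert-butyl. Also open, as far as these compounds go, is whether a plain cyclopropyl without its methyl would hold the number at the level of compound 3, and, with every reading taken at one dose, how the compounds would compare at other doses.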